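Aryl replacement on the sulfonamide of compound 1

A few compounds are considered here, and "the series" means these few. Any claim that something is new, unique, unknown or untested is made for them only; others in the source may bear on it.

Measured compounds:
compound 1 `CC1CCN(C2CCN(S(=O)(=O)c3ccc(C(C)(C)C)cc3)CC2)CC1` — > 5000 nM
compound 2 `Cc1cc(C)c(S(=O)(=O)N2CCC(N3CCC(O)CC3)CC2)c(C)c1` — 106 nM
compound 3 `Cc1cc(C)c(S(=O)(=O)N2CCC(N3CCCCC3)CC2)c(C)c1` — 2200 nM

In a functional assay on DLD-1 cells (Homo sapiens) for antiproliferative activity, read by CellTiter-Glo, with a stated time of 72 h (a higher number here means a weaker inhibitor, a lower number a stronger inhibitor), compound 1 gives > 5000 nM; this is a limit of the assay and not a number, as recorded in the limit of > 5000 nM in this assay, at which 1 of the 3 values shown sits. Compound 1 therefore stands at the weak end of the three values shown, with no number of its own. For the measured compounds named here, compound 2 gives 106 nM and compound 3 gives 2200 nM in this assay; the one step between them, a 21-fold higher number from compound 2 to compound 3 (1.32 log units; beyond the scatter), concerns a saturated ring carbon and not the aryl part.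

Compound 4 `CC1CCN(C2CCN(S(=O)(=O)c3ccc(-c4ccccc4F)cc3)CC2)CC1` differs from compound 1 by 2-fluorophenyl in place of tert-butyl on an aromatic carbon. No measured step touches the aromatic substituent, so there is nothing among the steps shown that bears directly on this change. Going by the values given here, the only guide is that compound 1 sits at the limit and that compound 3, the closest analogue with an unsubstituted piperidine, reaches a number only when the aryl group is mesityl.

For compound 4 the expectation is therefore a weak inhibitor, with a real chance that only a limit is reported again; the estimated value is 3000 nM, in the range 800 nM to 10000 nM, meaning an expected step of an at least 1.6-fold lower number from compound 1 to compound 4 (0.22 log units; that floor lies within the scatter).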

Compound 4, half-maximal inhibitory concentration: 5 nM
For compound 4 the middle estimate is 600-fold (2.78 log units) above the measured one; the whole stated range lies above it.
By their numbers in this assay, from the lowest: compound 4; then compound 2; then compound 3. At a limit, above all of these: compound 1.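

In this assay, 2-fluorophenyl in place of tert-butyl on an aromatic carbon, para to a large group, gives an at least 1000-fold lower number from compound 1 to compound 4 (3.00 log units; beyond the scatter), which shows that this position can govern the read-out in the series. The step also exceeds the one on the saturated ring carbon, a 21-fold higher number from compound 2 to compound 3 (1.32 log units; beyond the scatter), so the aromatic substituent is not a minor feature alongside the hydroxy group. The entry for compound 1 is a limit and not a number, and the step from it is therefore only a floor: the limit of > 5000 nM in this assay, at which 1 of the 4 values shown sits.

Going by these compounds, whether the gain depends on the added aromatic ring or on its fluorine remains open, and plain phenyl, 2-chlorophenyl or pyridyl at the same place would help to separate the two. Also open, on these data alone, is whether a hydroxy group on the saturated ring carbon, which marks the difference between compound 2 and compound 3, would change the number further when combined with the 2-fluorophenyl group of compound 4.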